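Triazole substituent swaps in a cytotoxicity series

A few compounds are considered here, and "the series" means these few. Any claim that something is new, unique, unknown or untested is made for them only; others in the source may bear on it.

Compound 1 `CCCCn1cc(Cn2nc(N)c3c(C(F)(F)F)cc(-c4ccccc4)nc32)nn1` in a functional assay on THP-1 cells (Homo sapiens) for cytotoxicity, read by MTT assay, with a stated time of 24 h (on this read-out lower numbers stand for stronger inhibition and higher numbers for weaker inhibition), gives 46.1 ug/mL. Compound 2 `CCCCCCCCCCn1cc(Cn2nc(N)c3c(C(F)(F)F)cc(-c4ccccc4)nc32)nn1` in this assay gives 48.7 ug/mL, and compound 3 `Nc1nn(Cc2cn(-c3ccc(O)c([N+](=O)[O-])c3)nn2)c2nc(-c3ccccc3)cc(C(F)(F)F)c12` in this assay gives 36.3 ug/mL. On these three numbers compound 1 stands between the other two, and all three sit within the usual scatter of one another: the step of a 1.1-fold higher number from compound 1 to compound 2 (0.02 log units; within the scatter), the step of a 1.3-fold lower number from compound 1 to compound 3 (0.10 log units; within the scatter) and the step of a 1.3-fold lower number from compound 2 to compound 3 (0.13 log units; within the scatter) are each too small to read as a real difference. The shared core of compound 1 is untouched in all three; only the group on the aromatic nitrogen of the triazole changes.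

Compound 4 `Nc1nn(Cc2cn(CC(=O)Nc3ccc(F)cc3Br)nn2)c2nc(-c3ccccc3)cc(C(F)(F)F)c12` is not yet measured. It differs from compound 1 as follows: (2-bromo-4-fluorophenyl)carbamoyl in place of propyl on a saturated chain carbon bound to an aromatic nitrogen. Among the measured compounds shown here, the steps that bear on this are the change from butyl to decyl, a 1.1-fold higher number from compound 1 to compound 2 (0.02 log units; within the scatter), and the change from butyl to 4-hydroxy-3-nitrophenyl, a 1.3-fold lower number from compound 1 to compound 3 (0.10 log units; within the scatter), which bring in a longer chain and an aromatic ring with donor and acceptor at the same nitrogen without moving the read-out. Compound 4 is therefore expected to show no step beyond the scatter, a 1.1-fold lower number from compound 1 to compound 4 (0.04 log units; within the scatter). The estimate for compound 4 in this assay is 42 ug/mL, with a range from 20 ug/mL to 85 ug/mL.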

Compound 4, half-maximal inhibitory concentration: 65.6 ug/mL
Compound 4: middle estimate off by 1.6-fold (0.19 log units), on the low side, and the stated range covers the measured number.
By their numbers in this assay, from the lowest: compounds 3, 1, 2 and 4 (each within the scatter of the next).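

In this assay the position on the aromatic nitrogen now also carries ((2-bromo-4-fluorophenyl)carbamoyl)methyl, which brings a carbonyl, the amide hydrogen and a bromine- and fluorine-bearing aromatic ring to the side chain, yet the steps of a 1.4-fold higher number from compound 1 to compound 4 (0.15 log units; within the scatter) and a 1.3-fold higher number from compound 2 to compound 4 (0.13 log units; within the scatter) both lie within the scatter. The step against the aromatic ring set directly on this nitrogen, a 1.8-fold higher number from compound 3 to compound 4 (0.26 log units; within the scatter), is the widest gap among the four compounds and also lies within the scatter, so butyl, decyl, 4-hydroxy-3-nitrophenyl and the new amide side chain cannot be told apart on this read-out. No supporting data are available to account for this flat result.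

The compounds shown leave open whether a carboxylic acid or a primary amine at the end of the chain on this nitrogen would give a step beyond the scatter. All four keep the shared core unchanged, so they also leave open whether methyl or hydrogen in place of the trifluoromethyl would move the read-out.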